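Alkylation on selenium in an aminoquinazoline cytotoxicity series

The source may report more compounds than this note shows. Statements on the series, on what has been measured and on what is new or still open speak of the compounds shown alone.

Three selenium-bearing analogues have been compared in a functional assay on HTB-54 cells (Homo sapiens) for cytotoxicity, read by MTT assay, with a stated time of 72 h; on this read-out lower numbers stand for stronger inhibition of growth and higher numbers for weaker inhibition of growth. Compound 1 `C[Se]c1nc(N)c2ccccc2n1` gives 88700 nM, compound 2 `CCCCC[Se]c1nc(NCc2ccccc2)c2ccccc2n1` gives 81100 nM, and compound 3 `Nc1nc([SeH])nc2ccccc12` gives 3630 nM. Compound 3 therefore stands at the lowest number of the three, with both other compounds well outside the usual scatter. Going by the values given here, the only step between compounds differing in one place is a 24-fold lower number from compound 1 to compound 3 (1.39 log units; beyond the scatter), so removing the methyl from the selenium sharply lowered the number.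

Compound 4 `CCCCC[Se]c1nc(N)c2ccccc2n1` differs from compound 3 by pentyl in place of hydrogen on a selenium. This is the reverse sense of the change from compound 1 to compound 3, only with a longer chain. Compound 2 also carries a pentyl on selenium, though with a further benzyl on the amine, and its number sits close to that of compound 1, within the scatter; the two values together suggest that alkyl chains of either length on the selenium are accompanied by high numbers. Compound 4 is therefore expected to move upward by a 19-fold higher number from compound 3 to compound 4 (1.29 log units; beyond the scatter) in this assay, back toward the level of compound 1 and compound 2. The estimate for compound 4 is 70000 nM, with a range from 20000 nM to 200000 nM.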

Compound 4, concentration for total growth inhibition: 84000 nM
Beside the measured number, compound 4's estimate is 1.2-fold (0.08 log units) below it; low and high end bracket the measured number.
By their numbers in this assay, from the lowest: compound 3; then compounds 2, 4 and 1 (each within the scatter of the next).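

With a 23-fold higher number from compound 3 to compound 4 (1.36 log units; beyond the scatter) in this assay, the large gap first seen with methyl on the selenium appears again with pentyl, so it no longer rests on a single alkyl group. The length of the chain makes no readable difference in this comparison, since a 1.1-fold lower number from compound 1 to compound 4 (0.02 log units; within the scatter) lies within the scatter; among the four compounds, those with methyl or pentyl on the selenium stay at high numbers, only compound 3 with hydrogen there stands apart, and none goes against this. The nitrogen on the aromatic ring adds a second finding: with pentyl on the selenium, a 1.0-fold higher number from compound 2 to compound 4 (0.02 log units; within the scatter) is also within the scatter, so hydrogen in place of benzyl on that nitrogen leaves no readable mark.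

No measurement shown here accounts for why hydrogen on the selenium gives so different a number from either alkyl group. As far as these compounds go, it remains open whether an acetyl group or a chain ending in a carboxylic acid on the selenium would keep the number near that of compound 3, and whether benzyl on the nitrogen would matter when the selenium carries hydrogen.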